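Triterpenoid esters and a carbamate: antiproliferative read-out on MCF7

This account rests on a few compounds, and the source may have more. Where it says the series, first, only, none or still open, it means among the compounds named here.

Measured so far:
- compound 1, `CC1=CCC2C(CC[C@@]2(C)O)C(C)(C)C1CC[C@@H]1[C@@]2(C)CCC(=O)C(C)(C)O[C@@H]2CC[C@]1(C)O`, gives > 50000 nM in a functional assay on MCF7 cells (Homo sapiens) for antiproliferative activity, read by MTT assay, with a stated time of 72 h; on this read-out lower numbers stand for stronger inhibition and higher numbers for weaker inhibition; this is a limit of the assay, not a number.
- compound 2, `CC1=CC[C@H]2[C@@H]1CC=C(C)[C@@H](CC[C@H]1[C@]3(C)CC[C@H](OC(=O)c4ccc(C)cc4)C(C)(C)O[C@H]3CC[C@@]1(C)O)C2(C)C`, gives > 50000 nM in this assay; again a limit, not a number.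
- compound 3, `CC1=CC[C@H]2[C@H](CC[C@]2(C)O)C(C)(C)[C@@H]1CC[C@H]1[C@]2(C)CC[C@H](OC(=O)NCc3ccccc3)C(C)(C)O[C@H]2CC[C@@]1(C)O`, gives 24500 nM in this assay.

Going by the values given here, compound 3 is therefore the only member with a measured number; the two other values are limits, and the limit of > 50000 nM in this assay, at which 2 of the 3 values shown sit, marks where they sit. Among the compounds with values here, no step between two measured compounds can be computed, so the reference for the next change is compound 3 alone.

Compound 4, `CC1=CC[C@H]2[C@H](CC[C@]2(C)O)C(C)(C)[C@@H]1CC[C@H]1[C@]2(C)CC[C@H](OC(=O)c3ccccc3C(F)(F)F)C(C)(C)O[C@H]2CC[C@@]1(C)O`, differs from compound 3 in one place: 2-(trifluoromethyl)phenyl in place of benzylamino on a carbonyl carbon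

The shared core and the oxygen next to the carbonyl group are unchanged. With compound 2 carrying a carbonyl-linked phenyl group and reporting only a limit, and compound 3 carrying benzylamino on the carbonyl carbon and reporting a number, the expectation for compound 4 is a step toward weaker inhibition or none beyond the scatter, stated as a 1.6-fold higher number from compound 3 to compound 4 (0.21 log units; within the scatter). Compound 4 is expected at 40000 nM, between 15000 nM and 100000 nM, with a substantial chance that the assay reports only a limit.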

Compound 4, half-maximal inhibitory concentration: 19200 nM
For compound 4 the middle estimate is 2.1-fold (0.32 log units) above the measured one; low and high end bracket the measured number.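

The step of a 1.3-fold lower number from compound 3 to compound 4 (0.11 log units; within the scatter) shows that, on this carbonyl carbon, 2-(trifluoromethyl)phenyl and benzylamino cannot be told apart in this assay on these two compounds. The entering group counts no hydrogen-bond donor, yet compound 4 gives 19200 nM as a number, so a measured value at this place does not rest on the donor of benzylamino. Compound 1 and compound 2 remain limits, not numbers: the limit of > 50000 nM in this assay, at which 2 of the 4 values shown sit.

A plain phenyl on the same carbonyl carbon would separate the share of the trifluoromethyl group from that of the aromatic ring alone. Whether an amine, a carboxylic acid or a longer chain at this place would move the value beyond the scatter stays open, as does the cause of the small difference, which no measured property in the series addresses.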